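Three Inactive Analogues and a Repositioned Chlorine

This account rests on a few compounds, and the source may have more. Where it says the series, first, only, none or still open, it means among the compounds named here.

All three measured compounds were tested in a functional assay on HepG2 cells (Homo sapiens) for antiproliferative activity, read by MTT assay, with a stated time of 48 h; on this read-out higher numbers stand for weaker inhibition and lower numbers for stronger inhibition.

Compound 1 `Cc1ccc(C)c(-n2nncc2CN2C(=O)C3(C(C#N)=C(N)Oc4c(N)cc5nc6ccccc6nc5c43)c3ccccc32)c1`: > 50000 nM
Compound 2 `Cc1cc(C)cc(-n2nncc2CN2C(=O)C3(C(C#N)=C(N)Oc4c(N)cc5nc6ccccc6nc5c43)c3ccccc32)c1`: > 50000 nM
Compound 3 `N#CC1=C(N)Oc2c(N)cc3nc4ccccc4nc3c2C12C(=O)N(Cc1cnnn1-c1ccc(Cl)cc1Cl)c1ccccc12`: > 50000 nM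

For compound 3 the figure is a limit of the assay, not a number. The same holds for its two companions, as the limit of > 50000 nM in this assay, at which 3 of the 3 values shown sit, records. Compound 4 `N#CC1=C(N)Oc2c(N)cc3nc4ccccc4nc3c2C12C(=O)N(Cc1cnnn1-c1cc(Cl)ccc1Cl)c1ccccc12` differs from compound 3 by 2,5-dichlorophenyl in place of 2,4-dichlorophenyl on an aromatic nitrogen. Among the measured compounds shown here, the steps that bear on this change are a step that the two limits leave unreadable from compound 1 to compound 3 and a step that the two limits leave unreadable from compound 2 to compound 3, and the related step that the two limits leave unreadable from compound 1 to compound 2 is no more readable. No size or direction of change can be drawn from these numbers. Compound 4 is therefore expected to remain at the same limit. The estimate for compound 4 is 60000 nM, between 20000 nM and 200000 nM. This corresponds to an expected step that the limit leaves unreadable from compound 3 to compound 4, none beyond the scatter.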

Compound 4, half-maximal inhibitory concentration: 33100 nM
Compound 4: the middle estimate sits 1.8-fold (0.26 log units) above what was measured, and the stated range covers the measured number.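

Compound 4 is the only one of the four to give a measured number in this assay, and it has the same atoms as compound 3, joined differently. The readable steps are an at least 1.5-fold lower number from compound 3 to compound 4 (0.17 log units; that floor lies within the scatter), an at least 1.5-fold lower number from compound 2 to compound 4 (0.17 log units; that floor lies within the scatter) and an at least 1.5-fold lower number from compound 1 to compound 4 (0.17 log units; that floor lies within the scatter), so each is only a floor and none shows a change beyond the scatter. The steps among compounds 1, 2 and 3 still cannot be read, and each of their values is a limit, not a number: the limit of > 50000 nM in this assay, at which 3 of the 4 values shown sit.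

The compounds shown leave open how far compound 4 truly lies from the other three. They also leave open whether an amine or a carboxylic acid on this phenyl ring, or a longer chain in its place, would give a lower number.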